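Benzylsulfanyl for chloro on a benzimidazole-like core

This account rests on a few compounds, and the source may have more. Where it says the series, first, only, none or still open, it means among the compounds named here.

Compound 1 `OCC(CO)OCn1c(Cl)nc2cc(Cl)c(Cl)cc21`: > 100000 nM
Compound 2 `OCC(CO)OCn1c(Cl)nc2c(Cl)c(Cl)ccc21`: > 100000 nM
Compound 3 `CN(C)c1nc2c(Cl)cc(Cl)cc2n1COC(CO)CO`: > 100000 nM

All three measured compounds were tested in a functional assay on KB cells (Homo sapiens) for inhibition; a lower number here means a stronger inhibitor, a higher number a weaker inhibitor. In this assay compound 1 gives > 100000 nM, which is a limit of the assay and not a number. Compound 2 gives > 100000 nM in this assay, again a limit rather than a number. Compound 3 likewise gives > 100000 nM, a limit. Compound 2 therefore stands only at a limit, and the two other values shown are limits as well; (the limit of > 100000 nM in this assay, at which 3 of the 3 values shown sit).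

Compound 4 `OCC(CO)OCn1c(SCc2ccccc2)nc2c(Cl)c(Cl)ccc21` is not yet measured in this assay. It differs from compound 2 in one place: benzylsulfanyl in place of chloro on an aromatic carbon. In words, benzylsulfanyl takes the place of chloro on an aromatic carbon, the carbon that sits between two ring nitrogen atoms of the five-membered aromatic ring.

Among the measured compounds shown here, no step between measured compounds is available, so there is no measured guide to how this change acts. Since every shown value is a limit, a small step in either direction cannot be told apart from none beyond the scatter, and the expectation is that the step from compound 2 to compound 4 is an at least 1.2-fold lower number from compound 2 to compound 4 (0.09 log units; that floor lies within the scatter), which is none beyond the scatter. For compound 4 the estimate in this assay is 80000 nM, with a range from 10000 nM to 300000 nM, and a real chance that only a limit is reported.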

Compound 4, half-maximal inhibitory concentration: 60000 nM
Beside the measured number, compound 4's estimate is 1.3-fold (0.12 log units) above it; low and high end bracket the measured number.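

Among the compounds shown here, compound 4 is the first compound here to give a measured number rather than a limit in this assay, so the carbon between two ring nitrogen atoms is the first place in this set where a change has moved a result off that limit. Putting benzylsulfanyl, with its 8 heavy atoms and six-membered aromatic ring, in place of chloro gives an at least 1.6-fold lower number from compound 2 to compound 4 (0.22 log units; that floor lies within the scatter), which shows that this much larger group still leaves a readable value, though the floor of the step alone does not establish a real gain. The true size of the step stays unknown because compound 2 has only a limit and no number: the limit of > 100000 nM in this assay, at which 3 of the 4 values shown sit.

The compounds shown leave open whether any gain depends on the sulfur or on the aromatic ring, a question that methylsulfanyl or a benzylamine group on the same carbon could help to settle. Also open, as far as these compounds go, is whether benzylsulfanyl would act in the same way on the core of compound 1, where the two chlorines sit elsewhere, or whether a carboxylic acid on its ring would change the result.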